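Fluorine on the Benzyl Group at an Unreadable Limit

This account rests on a few compounds, and the source may have more. Where it says the series, first, only, none or still open, it means among the compounds named here.

Compound 1 `CCOC(=O)C(=O)CC(=O)/C=C/c1cn(-c2ccc(Cl)cc2)c2ccccc12` and compound 2 `CCOC(=O)C(=O)CC(=O)/C=C/c1cn(Cc2ccccc2)c2ccccc12` share one core and differ only in the group on the aromatic nitrogen, where compound 2 carries benzyl in place of 4-chlorophenyl. In an assay on isolated protein for inhibition of DNA nucleotidylexotransferase (Homo sapiens), read by scintillation counting, with a stated time of 10 min (on this read-out lower numbers stand for stronger inhibition and higher numbers for weaker inhibition), compound 1 gives > 40 uM, a limit of the assay rather than a number. In this assay compound 2 gives > 40 uM, also a limit. The step that the two limits leave unreadable from compound 1 to compound 2 therefore has no readable size. Compound 3 `CCOC(=O)C(=O)CC(=O)/C=C/c1cn(Cc2ccc(F)cc2)c2ccccc12` differs from compound 2 by fluoro in place of hydrogen on an aromatic carbon. Going by the values given here, with both measured values sitting at the limit of > 40 uM in this assay, at which 2 of the 2 values shown sit, no measured step shows how such a change acts. Compound 3 is expected to remain near the limit, estimated at 60 uM within 25 uM to 150 uM, a step that the limit leaves unreadable from compound 2 to compound 3.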

Compound 3, concentration for 50% inhibition: > 40 uM
Compound 3: no number, only a limit; the forecaster's own chance of this, stated with the estimate: 80%; the middle value lies beyond the limit too.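

No step among compound 1, compound 2 and compound 3 can be read in this assay, as each gives a limit and not a number: the limit of > 40 uM in this assay, at which 3 of the 3 values shown sit.

From the compounds shown here alone, whether any of these groups on the aromatic nitrogen, with or without fluoro, changes inhibition at all stays open.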